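Swapping the sulfone ring for morpholine on the amide

A few compounds are considered here, and "the series" means these few. Any claim that something is new, unique, unknown or untested is made for them only; others in the source may bear on it.

Compound 1 `CCN(CC)S(=O)(=O)c1ccc(S(=O)(=O)N2CCC[C@@H](C(=O)N3CCS(=O)(=O)CC3)C2)cc1`: 900 nM
Compound 2 `O=C([C@@H]1CCCN(S(=O)(=O)c2ccc(S(=O)(=O)N3CC[C@H](O)C3)cc2)C1)N1CCC(F)(F)CC1`: 590 nM

Of the compounds shown here, two have been measured in a functional assay on MIA PaCa-2 cells (Homo sapiens) for inhibition, read by MTT assay, with a stated time of 7 days; on this read-out higher numbers stand for weaker inhibition and lower numbers for stronger inhibition. Compound 1 gives 900 nM, and compound 2 gives 590 nM; the two numbers lie within the usual scatter of each other, so compound 1 stands alongside compound 2 rather than apart from it. Compound 3 `CCN(CC)S(=O)(=O)c1ccc(S(=O)(=O)N2CCC[C@@H](C(=O)N3CCOCC3)C2)cc1` has not been measured. It differs from compound 1 in one place: morpholin-4-yl in place of 1,1-dioxothiomorpholin-4-yl on a carbonyl carbon. Among the compounds with values here, no pair of measured compounds separated by a single change has been measured, so there is no step to lean on; the change is expected to move the number little, if at all, beyond the scatter. For compound 3 the estimated step in this assay is a 1.2-fold higher number from compound 1 to compound 3 (0.09 log units; within the scatter). Compound 3 is therefore expected to give about 1100 nM, within a range from 450 nM to 2700 nM.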

Compound 3, half-maximal inhibitory concentration: 350 nM
Compound 3: the middle estimate sits 3.1-fold (0.50 log units) above what was measured; the measured number lies below the stated range.
By their numbers in this assay, from the lowest: compounds 3, 2 and 1 (each within the scatter of the next, the first and the last beyond it).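

In this assay morpholin-4-yl in place of 1,1-dioxothiomorpholin-4-yl on a carbonyl carbon gives the only single-place comparison among these compounds (a 2.6-fold lower number from compound 1 to compound 3 (0.41 log units; beyond the scatter)), a modest step but one beyond the scatter. It shows that this position is not indifferent to its group, even though both groups are six-membered non-aromatic rings with 2 hetero atoms and the rest of the molecule stays the same. No measurement offered here accounts for the direction or size of the step.

As far as these compounds go, whether the same swap gives a similar step on the core of compound 2 stays open, since this change has been read on one core only. Also open, from the compounds shown here alone, is how the number would move with a piperazin-1-yl ring or an open-chain diethylamino group on the same carbonyl carbon.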